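This account rests on a few compounds, and the source may have more. Where it says the series, first, only, none or still open, it means among the compounds named here.

Measured so far in a functional assay on the whole organism (strain Wistar) for inhibition, with Rattus norvegicus as the target, read by paw edema, with stated times of 60 min and 24 h, at a dose of 100 mg/kg by the oral route; on this read-out lower numbers stand for less inhibition and higher numbers for more inhibition at the one dose given (going by the name of the read-out):
compound 1 `CCNC(=O)CC1CCc2cc(OC)c(OC)cc21`: 33.3%
compound 2 `CCN(CC)C(=O)CC1CCc2cc(OC)c(OC)cc21`: 16.7%

Compound 2 stands lowest of the two numbers, with compound 1 the nearest and beyond the scatter above it. Going by the values given here, the only measured step, a number 16.6 percentage points lower from compound 1 to compound 2 (beyond the scatter), is the reference: ethyl in place of hydrogen on an amide-type nitrogen, modest in size. Compound 3 `CCCCCCNC(=O)CC1CCc2cc(OC)c(OC)cc21` carries the change (hexylamino in place of diethylamino on a carbonyl carbon), which brings back the amide hydrogen that compound 1 has while lengthening the chain on the nitrogen. Among the compounds with values here, the measured step bears on it only in part, since no measured pair varies chain length on the nitrogen. A rise of roughly the size seen, in reverse, is expected, because compound 1 with its amide hydrogen gives 33.3%; the expected step is a number 13.3 percentage points higher from compound 2 to compound 3 (beyond the scatter). Compound 3 is estimated at 30%, within 10% to 52%.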

Compound 3, a percentage reported as inhibition, in the whole organism at one dose (the size of the read-out at that dose, not a potency): 45.5%
For compound 3 the middle estimate is 15.5 percentage points below the measured one, and the stated range covers the measured number.
By their numbers in this assay, from the lowest: compound 2; then compound 1; then compound 3.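

In this assay hexylamino in place of diethylamino on a carbonyl carbon gives a number 28.8 percentage points higher from compound 2 to compound 3 (beyond the scatter) and so places the number above that of either earlier compound. The second step, a number 12.2 percentage points higher from compound 1 to compound 3 (beyond the scatter) for butyl in place of hydrogen on a saturated chain carbon, two bonds along the chain from an amide-type nitrogen, shows what the earlier pair could not: with the amide hydrogen kept, the length of the chain on the nitrogen also moves the read-out. Nothing on hand explains either step.

As far as these compounds go, two secondary amides make no trend, so it remains open whether an octyl chain would raise the number further or a butyl chain would fall between them. Also open, from the compounds shown here alone, is what a cyclohexyl group or a chain ending in a carboxylic acid would give at this nitrogen.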